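The compounds below may be only part of what the source reports. "The series", "measured", "known", "first", "only" and "open" are said of these compounds alone.

Measured so far in a functional assay on GBM2 cells (Homo sapiens) for antiproliferative activity, read by WST assay, with a stated time of 72 h; on this read-out higher numbers stand for weaker inhibition and lower numbers for stronger inhibition

Compound 1 `O=C(Nc1cccc(F)c1)Nc1cc2ncncc2cc1OCc1ccccc1Cl` gives 3200 nM 
Compound 2 `O=C(Nc1cc2ncncc2cc1OCc1cccc(F)c1)Nc1cccc2ccccc12` gives 1400 nM 

Of these two numbers, compound 2 has the lower, and the gap up to compound 1 lies beyond the scatter. The next compound to be tested is compound 3 `O=C(Nc1cc2ncncc2cc1OCc1ccccc1Cl)Nc1cccc2ccccc12` and it differs from compound 2 in one place. On a saturated chain carbon bound to an oxygen on an aromatic ring, 2-chlorophenyl stands in place of 3-fluorophenyl (2-chlorophenyl in place of 3-fluorophenyl on a saturated chain carbon bound to an oxygen on an aromatic ring). Among the measured compounds shown here, no measured pair shows this change alone, so any expectation is only loosely supported. Compound 1 also carries the 2-chlorobenzyl group, and its value of 3200 nM shows that this group occurs in the weaker of the two measured compounds. That is slight evidence, and it points at most toward somewhat higher numbers. In this assay no step beyond the scatter is therefore expected. The expected change is a 1.1-fold higher number from compound 2 to compound 3 (0.06 log units; within the scatter) and it is estimated to stay within the scatter. For compound 3 the estimated value is 1600 nM within an expected range (650 nM to 3800 nM).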

Compound 3, half-maximal inhibitory concentration: 2900 nM
Compound 3: the middle estimate sits 1.8-fold (0.26 log units) below what was measured; low and high end bracket the measured number.
By their numbers in this assay, from the lowest: compound 2; then compounds 3 and 1 (each within the scatter of the next).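

In this assay, the change from 3-fluorobenzyl to 2-chlorobenzyl gives a 2.1-fold higher number from compound 2 to compound 3 (0.32 log units; beyond the scatter). Among the compounds shown here, this is the first reading of this change alone, and it shows that, with naphthalen-1-yl held on the amide-type nitrogen, the choice of group at this place can shift the number beyond the scatter, though only modestly. With 2-chlorophenyl held at that place, naphthalen-1-yl in place of 3-fluorophenyl on an amide-type nitrogen gives a 1.1-fold lower number from compound 1 to compound 3 (0.04 log units; within the scatter), which stays within the scatter, so this pair shows no clear effect of that change. No measurement available here bears on what lies behind either step.

Because the two groups differ in both the halogen and its position, the compounds shown cannot tell which of the two matters, and a comparison with 2-fluorophenyl or 3-chlorophenyl at the same place would separate them. Going by these compounds, it also remains open how an unsubstituted phenyl, a pyridine ring or a chain carrying an amine would read there.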